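The source may hold more compounds than are shown below. What is called first, only, known or untested is meant among the compounds shown, and "the series" means these compounds.

Measured compounds: compound 1 `COc1ccc(Cc2nnc3n2NC(c2ccco2)S3)cc1OC` with 24.6%; compound 2 `COc1ccc(Cc2nnc3n2NC(c2ccc[nH]2)S3)cc1OC` with 21.5%.

In a functional assay on the whole organism (strain Wistar Albino) for inhibition, with Rattus norvegicus as the target, read by paw edema, with a stated time of 4 h, at a dose of 20 mg/kg (on this read-out higher numbers stand for more inhibition at the one dose given (going by the name of the read-out) and lower numbers for less inhibition), compound 2 gives 21.5%, and the step of a number 3.1 percentage points lower from compound 1 to compound 2 (within the scatter) lies within the scatter, so compound 1 and compound 2 are not separated. Compound 3 `COc1ccc(Cc2nnc3n2NC(c2cccn2C)S3)cc1OC` differs from compound 2 by methyl in place of hydrogen on an aromatic nitrogen. For the measured compounds named here, no measured step touches this aromatic nitrogen; the one step known swaps one five-membered ring for another and bears only loosely. No change beyond the scatter is therefore expected in this assay, the estimated step being a number 0.5 percentage points higher from compound 2 to compound 3 (within the scatter). Compound 3 is expected to give 22%, within 10% to 34%.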

Compound 3, a percentage reported as inhibition, in the whole organism at one dose (the size of the read-out at that dose, not a potency): 19.9%
Beside the measured number, compound 3's estimate is 2.1 percentage points above it; the measured number falls inside the stated range.
By their numbers in this assay, from the lowest: compounds 3, 2 and 1 (each within the scatter of the next).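

Methyl in place of hydrogen on the aromatic nitrogen gives a number 1.6 percentage points lower from compound 2 to compound 3 (within the scatter) in this assay, so the first change at this position does not separate the two compounds. 1-Methyl-1H-pyrrol-2-yl in place of furan-2-yl gives a number 4.7 percentage points lower from compound 1 to compound 3 (within the scatter) and likewise leaves the compounds unseparated at this dose. Nothing available explains this result.

Going by these compounds, whether a longer chain such as n-butyl, or a benzyl group, on this nitrogen would also stay within the scatter remains open. So does whether an amine on that chain would separate the compounds.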